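The source may hold more compounds than are shown below. What is called first, only, known or untested is meant among the compounds shown, and "the series" means these compounds.

Three compounds share one core and differ only in the group attached to one aromatic carbon of that core. Compound 1 `C[C@H](NC(=O)c1c(C2CC2)nnn1Cc1ccc(C(F)(F)F)cc1)c1ccc(C(=O)O)cc1` carries a cyclopropyl group there and in a functional assay on CHO cells for antagonist activity at prostaglandin E2 receptor EP4 subtype (Homo sapiens), read by calcium flux, with a stated time of 15 min (on this read-out lower numbers stand for stronger inhibition and higher numbers for weaker inhibition), gives 52.1 nM. Compound 2 `C[C@H](NC(=O)c1c(C2CCCCC2)nnn1Cc1ccc(C(F)(F)F)cc1)c1ccc(C(=O)O)cc1` carries a cyclohexyl group and in this assay gives 161 nM. Compound 3 `C[C@H](NC(=O)c1c(C2=CCCCC2)nnn1Cc1ccc(C(F)(F)F)cc1)c1ccc(C(=O)O)cc1` carries a cyclohex-1-en-1-yl group and in this assay gives 183 nM, the highest of the three numbers, although its gap to compound 2, a 1.1-fold higher number from compound 2 to compound 3 (0.06 log units; within the scatter), lies within the scatter. The two steps that reach beyond the scatter are a 3.1-fold higher number from compound 1 to compound 2 (0.49 log units; beyond the scatter) and a 3.5-fold higher number from compound 1 to compound 3 (0.55 log units; beyond the scatter).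

Compound 4 `C=CCc1nnn(Cc2ccc(C(F)(F)F)cc2)c1C(=O)N[C@@H](C)c1ccc(C(=O)O)cc1` differs from compound 3 in one place: allyl in place of cyclohex-1-en-1-yl on an aromatic carbon. The step that bears most directly on this change is a 3.5-fold higher number from compound 1 to compound 3 (0.55 log units; beyond the scatter), read in reverse, since it is the one case where a ring of six carbons at this place was exchanged for a group of fewer atoms. The step of a 1.1-fold higher number from compound 2 to compound 3 (0.06 log units; within the scatter) adds that removing the double bond alone changed little. A modest move toward a lower number is therefore expected, a 2.2-fold lower number from compound 3 to compound 4 (0.33 log units; beyond the scatter). Compound 4 is estimated at 85 nM, with a range from 35 nM to 200 nM.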

Compound 4, half-maximal inhibitory concentration: > 1000 nM
Compound 4 gave a limit, no number; the forecaster's own chance of this, stated with the estimate: 0%; middle value at least 11-fold (1.07 log units) away from the limit.
By their numbers in this assay, from the lowest: compound 1; then compounds 2 and 3 (each within the scatter of the next). At a limit, above all of these: compound 4.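

Compound 4 gave a limit of the assay and not a number: the limit of > 1000 nM in this assay, at which 1 of the 4 values shown sits. Its steps read as an at least 5.4-fold higher number from compound 3 to compound 4 (0.73 log units; beyond the scatter) and an at least 6.2-fold higher number from compound 2 to compound 4 (0.79 log units; beyond the scatter) and an at least 19-fold higher number from compound 1 to compound 4 (1.28 log units; beyond the scatter) and all of them start from that limit. Going by these compounds alone, the earlier compounds hinted that the smaller group gave the lower number at this place on the shared core, but compound 4 goes against that hint: among the four compounds, allyl is the only group without a ring, and it stands above all three ring-bearing compounds.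

With a single open-chain group, ring and chain cannot be separated from other differences between allyl and the rings. From the compounds shown here alone, a saturated propyl chain or a cyclobutyl ring at this place would be the closest neighbours still open.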